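Opening the piperidine amide: compound 1 to compound 4

The source may hold more compounds than are shown below. What is called first, only, known or untested is meant among the compounds shown, and "the series" means these compounds.

Measured compounds in an assay on HEK293 cells for displacement of a labelled ligand from NPC1-like intracellular cholesterol transporter 1 (Homo sapiens); a higher number here means a weaker inhibitor, a lower number a stronger inhibitor:
compound 1 `CC(C)(C)c1ccc(C(=O)N2CCC3(CC2)C(=O)N(CC(=O)N2CCCC(C(N)=O)C2)CN3c2ccccc2)cc1`, 16900 nM
compound 3 `NC(=O)C1CCCN(C(=O)CN2CN(c3ccccc3)C3(CCN(C(=O)c4ccc(C5CCCCC5)cc4)CC3)C2=O)C1`, 3100 nM
compound 2 `CCc1nn(CC)c(C2CCN(C(=O)CN3CN(c4ccccc4)C4(CCN(C(=O)c5ccc(C6CCCCC6)cc5)CC4)C3=O)CC2)c1C`, "not determined" (no result reported)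

Going by the values given here, compound 1 gives the highest of the two numbers recorded in this assay; its nearest neighbour is compound 3, and the single measured step, a 5.5-fold lower number from compound 1 to compound 3 (0.74 log units; beyond the scatter), is modest but beyond the scatter. Compound 4 `CC(C)(C)c1ccc(C(=O)N2CCC3(CC2)C(=O)N(CC(=O)NCCCCN)CN3c2ccccc2)cc1` differs from compound 1 in a different place: (4-aminobutyl)amino in place of 3-carbamoylpiperidin-1-yl on a carbonyl carbon. Among the compounds with values here, no measured step touches this position, since the only recorded change sits on the aromatic carbon. With nothing to guide the direction, the step of a 1.1-fold lower number from compound 1 to compound 4 (0.05 log units; within the scatter) is expected to lie within the scatter. Compound 4 is therefore estimated at 15000 nM, with a range from 5000 nM to 45000 nM.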

Compound 4, half-maximal inhibitory concentration: 14500 nM
Estimate against measurement, compound 4: 1.0-fold (0.01 log units) above, within the range that was stated.
By their numbers in this assay, from the lowest: compound 3; then compounds 4 and 1 (each within the scatter of the next).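

In this assay, compounds 1 and 3 carry the same group at this carbonyl carbon, so they say nothing about changing it. The step of a 1.2-fold lower number from compound 1 to compound 4 (0.07 log units; within the scatter) now shows that (4-aminobutyl)amino, an open chain with no ring, can stand in place of 3-carbamoylpiperidin-1-yl while the number stays within the scatter. Nothing measured here explains this result. On these data alone, whether a longer chain, or a carboxylic acid in place of the amino group, would do the same remains open. So does whether the chain would hold alongside the cyclohexyl group of compound 3.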